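From a dichlorophenoxy ether to a methoxyphenyl thioether

This account rests on a few compounds, and the source may have more. Where it says the series, first, only, none or still open, it means among the compounds named here.

Compound 1, with the structure `Nc1cc(N)c2nc(-c3ccccc3)c(Oc3ccc(Cl)c(Cl)c3)nc2c1`, was tested in a functional assay on UACC-62 cells (Homo sapiens) for inhibition, read by sulforhodamine B assay, with a stated time of 48 h; on this read-out lower numbers stand for higher toxicity in this test and higher numbers for lower toxicity in this test. In this assay compound 1 reached only the limit < 100000 nM, which is a limit of the assay and not a number. Among the measured compounds shown here, the one firm number here belongs to compound 2, `COc1cc(CNc2nc3cc(N)cc(N)c3nc2-c2ccccc2)cc(OC)c1OC`, which in this assay gives 29500 nM. Compound 3, `COc1ccc(Sc2nc3cc(N)cc(N)c3nc2-c2ccccc2)cc1`, has not yet been measured in this assay. It differs from compound 1 in one place: (4-methoxyphenyl)sulfanyl in place of 3,4-dichlorophenoxy on an aromatic carbon, the carbon sitting next to the ring nitrogen and ortho to a phenyl group. For the measured compounds named here, because compound 1 shows only (the limit of < 100000 nM in this assay, at which 1 of the 2 values shown sits), no measured step is available to set the size of this change. The estimated step from compound 1 to compound 3 is a step that the limit leaves unreadable from compound 1 to compound 3, with no direction claimed beyond the scatter. Compound 3 is therefore expected to give about 30000 nM, within a range from 8000 nM to 100000 nM.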

Compound 3, concentration lethal to 50% of the cells: < 100000 nM
Compound 3: no number, only a limit; the forecaster's own chance of this, stated with the estimate: 35%; the middle value does not contradict the limit.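

Compound 1 and compound 3 each show only a limit of the assay and not a number, so no step between them can be read: the limit of < 100000 nM in this assay, at which 2 of the 3 values shown sit.

From the compounds shown here alone, whether (4-methoxyphenyl)sulfanyl in place of 3,4-dichlorophenoxy shifts the result in this assay stays open.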